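The source may hold more compounds than are shown below. What is called first, only, known or untested is meant among the compounds shown, and "the series" means these compounds.

Measured compounds in a functional assay on HeLa cells (Homo sapiens) for antiproliferative activity, read by sulforhodamine B assay, with a stated time of 48 h; on this read-out lower numbers stand for stronger inhibition and higher numbers for weaker inhibition:
compound 1, `CC(=O)NS(=O)(=O)c1ccc(N/C(S)=N\c2ccnc3cc(C(F)(F)F)ccc23)cc1`, 37600 nM
compound 2, `N=C(N)NS(=O)(=O)c1ccc(N/C(S)=N\c2ccnc3cc(C(F)(F)F)ccc23)cc1`, 23900 nM

Going by the values given here, compound 2 sits at one end of the two measured values, with compound 1 as its only neighbour; the single recorded step, a 1.6-fold lower number from compound 1 to compound 2 (0.20 log units; within the scatter), places the two within the scatter of each other, so the pair gives no resolved direction on the shared core of compound 2.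

Compound 3, `Cc1cc(NS(=O)(=O)c2ccc(N/C(S)=N\c3ccnc4cc(C(F)(F)F)ccc34)cc2)on1`, carries the change (a group of 6 heavy atoms (4 carbon, 1 nitrogen, 1 oxygen; one five-membered aromatic ring with 2 hetero atoms) in place of a group of 3 heavy atoms (1 carbon, 2 nitrogen; no ring), on a sulfonamide nitrogen). Among the compounds with values here, the only measured step that touches the same position is a 1.6-fold lower number from compound 1 to compound 2 (0.20 log units; within the scatter), a swap of one small acyclic group for another on the sulfonamide nitrogen, and it moved nothing beyond the scatter. Within the data shown here, no measured step covers the entry of a five-membered aromatic ring at this nitrogen, so the size of the move cannot be read from the series; the precedent at this position argues for a step no larger than the scatter in this assay, in either direction.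

Compound 3 is therefore expected to give about 20000 nM in this assay, within 6000 nM to 65000 nM, an estimated step of a 1.2-fold lower number from compound 2 to compound 3 (0.08 log units; within the scatter).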

Compound 3, half-maximal inhibitory concentration: 60200 nM
Beside the measured number, compound 3's estimate is 3.0-fold (0.48 log units) below it, within the range that was stated.
By their numbers in this assay, from the lowest: compounds 2, 1 and 3 (each within the scatter of the next, the first and the last beyond it).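

In this assay, the sulfonamide nitrogen now gives its first step beyond the scatter: a 2.5-fold higher number from compound 2 to compound 3 (0.40 log units; beyond the scatter), modest in size, with 3-methyl-1,2-oxazol-5-yl entering and the acyclic group of compound 2 leaving. The same entering group set against the acetyl of compound 1 gives a 1.6-fold higher number from compound 1 to compound 3 (0.20 log units; within the scatter), which lies within the scatter, so the entry of this five-membered aromatic ring separates compound 3 from compound 2 only, and compound 1 and compound 3 cannot be told apart in this read-out. The position therefore tolerates a ring at this nitrogen with at most a modest shift in the series shown, and no information is available to explain the difference between compound 2 and compound 3.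

Still open, going by these compounds, is whether any group on this sulfonamide nitrogen, such as a phenyl ring, a simple amine or a carboxylic acid on a short chain, takes the number far outside the narrow band of these three compounds. Also open, on these data alone, is whether the step from compound 2 follows the ring itself or its methyl group, a question that the unsubstituted 1,2-oxazol-5-yl group would address.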